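Estimating compound 4 from its benzoxazole-bearing neighbour

The compounds below may be only part of what the source reports. "The series", "measured", "known", "first", "only" and "open" are said of these compounds alone.

Measured so far in a functional assay on MCF7 cells (Homo sapiens) for cytotoxicity, read by MTT assay, with a stated time of 24 h; a higher number here means a weaker inhibitor, a lower number a stronger inhibitor
- compound 1 `COc1cc2ncnc(Nc3ccc(F)c(Cl)c3)c2cc1OCCCSc1nc2ccccc2o1` gives 4050 nM
- compound 2 `COc1cc2ncnc(Nc3cccc(C(F)(F)F)c3)c2cc1OCCCSc1nc2ccccc2o1` gives 4030 nM
- compound 3 `COc1ccc(Nc2ncnc3cc(OC)c(OCCCSc4nc5ccccc5o4)cc23)cc1` gives 13100 nM

Compound 3 is the weakest of the three, with a 3.2-fold higher number from compound 1 to compound 3 (0.51 log units; beyond the scatter) and a 3.3-fold higher number from compound 2 to compound 3 (0.51 log units; beyond the scatter) on the way to it. Compound 4 `CCCCc1nc(Cl)c(C=O)n1CCCOc1cc2c(Nc3ccc(OC)cc3)ncnc2cc1OC` keeps the 4-methoxyphenyl group and differs from compound 3 in one place (2-butyl-4-chloro-5-formyl-1H-imidazol-1-yl in place of (1,3-benzoxazol-2-yl)sulfanyl on a saturated chain carbon, three bonds along the chain from an oxygen on an aromatic ring). The two steps above are modest, but they swap the group on nitrogen and leave this place untouched. For the measured compounds named here, no measured step covers the new change, so in this assay no shift beyond the scatter is expected, and the uncertainty stays wide. The estimate amounts to a 1.3-fold lower number from compound 3 to compound 4 (0.12 log units; within the scatter) as the expected step. Compound 4 is estimated at 10000 nM (expected range 3000 nM to 30000 nM).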

Compound 4, half-maximal inhibitory concentration: 14000 nM
Beside the measured number, compound 4's estimate is 1.4-fold (0.15 log units) below it; the range from low to high includes it.
By their numbers in this assay, from the lowest: compounds 2 and 1 (each within the scatter of the next); then compounds 3 and 4 (each within the scatter of the next).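

Replacing the group on a saturated chain carbon, three bonds along the chain from an oxygen on an aromatic ring, gives a 1.1-fold higher number from compound 3 to compound 4 (0.03 log units; within the scatter) in this assay. The two-ring (1,3-benzoxazol-2-yl)sulfanyl and the one-ring, sulfur-free 2-butyl-4-chloro-5-formyl-1H-imidazol-1-yl therefore read alike at this place, with the 4-methoxyphenyl group kept. No supporting measurement explains this match.

On these data alone, whether an amine or a carboxylic acid at this place would shift the number remains open. So does whether 2-butyl-4-chloro-5-formyl-1H-imidazol-1-yl would read the same with the 3-chloro-4-fluorophenyl group on nitrogen.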